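Chloro to Fluoro: Expected Change in Cell Toxicity

The compounds below may be only part of what the source reports. "The series", "measured", "known", "first", "only" and "open" are said of these compounds alone.

Of the compounds shown here, three have been measured in an ADME assay on HEp-2 cells (Homo sapiens) for cytotoxicity, read by MTT assay, with a stated time of 3 days; on this read-out higher numbers stand for lower toxicity in this test and lower numbers for higher toxicity in this test. Compound 1 `CC[C@H](CCn1cncn1)c1ccc(F)cc1` gives 103 ug/mL, compound 2 `CCC[C@H](CCn1cncn1)c1ccc(F)cc1` gives 39.3 ug/mL, and compound 3 `CCCC[C@H](CCn1cncn1)c1ccc(Cl)cc1` gives 20.2 ug/mL. Compound 3 stands at the lowest of these three numbers, though its gap to compound 2 lies within the scatter, while its gap to compound 1 lies beyond it. Going by the values given here, the only step that can be isolated, a 2.6-fold lower number from compound 1 to compound 2 (0.42 log units; beyond the scatter), concerns a longer chain and not the halogen. Compound 4 `CCCC[C@H](CCn1cncn1)c1ccc(F)cc1` differs from compound 3 in one place: fluoro in place of chloro on an aromatic carbon. Among the compounds with values here, no measured pair isolates this swap: compounds 2 and 3 differ both in the chain and in the halogen, so their two values cannot separate the two changes. Without a direct precedent, the expectation is a small step, and the estimated step is a 1.5-fold higher number from compound 3 to compound 4 (0.17 log units; within the scatter), within the scatter. Compound 4 is therefore estimated at 30 ug/mL, with a range from 12 ug/mL to 80 ug/mL.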

Compound 4, half-maximal cytotoxic concentration: 38.5 ug/mL
The estimate for compound 4 lay 1.3-fold (0.11 log units) below the measured number; the range from low to high includes it.
By their numbers in this assay, from the lowest: compounds 3, 4 and 2 (each within the scatter of the next); then compound 1.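

In this assay the swap of fluoro in place of chloro on an aromatic carbon, para to a large group, can now be read alone: it gives a 1.9-fold higher number from compound 3 to compound 4 (0.28 log units; within the scatter) and so cannot be told apart from repeat-measurement variation at this position. On the chain side, adding ethyl gives a 2.7-fold lower number from compound 1 to compound 4 (0.43 log units; beyond the scatter) and stays beyond the scatter, whereas the added methyl gives a 1.0-fold lower number from compound 2 to compound 4 (0.01 log units; within the scatter) and so shows no readable change on this longer chain. Nothing at hand bears on why these steps take the sizes they do.

Going by these compounds, only fluoro and chloro appear at this ring position, so what bromo or a nitrile would do there remains open. Also open, on these data alone, is whether a pentyl chain, or an amine on the chain, would move the number further.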